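The source may report more compounds than this note shows. Statements on the series, on what has been measured and on what is new or still open speak of the compounds shown alone.

Measured in a functional assay on QGY-7703 cells (Homo sapiens) for cytotoxicity, read by MTT assay, with a stated time of 24 h; a lower number here means a stronger inhibitor, a higher number a weaker inhibitor:
- compound 1 `COc1cc(/C=C2\CN(S(=O)(=O)c3ccc(F)cc3)C/C(=C\c3cc(OC)cc(OC)c3)C2=O)cc(OC)c1`: 11400 nM
- compound 2 `O=C1/C(=C/c2cccc([N+](=O)[O-])c2)CN(S(=O)(=O)c2ccc(F)cc2)C/C1=C\c1ccccc1F`: 14900 nM
- compound 3 `COc1cc(/C=C2\CN(S(=O)(=O)c3ccc(F)cc3)C/C(=C\c3ccccc3F)C2=O)cc(OC)c1OC`: 13300 nM

Compound 3, at 13300 nM, cannot be separated from the other two compounds, since all of these numbers lie within the scatter of each other. The next compound to consider is compound 4 `COc1cc(/C=C2\CN(S(=O)(=O)c3ccc(F)cc3)C/C(=C\c3ccccc3F)C2=O)cc(OC)c1`. Its change from compound 3 is hydrogen in place of methoxy on an aromatic carbon, which turns 3,4,5-trimethoxyphenyl into 3,5-dimethoxyphenyl. The fluorophenyl group stays as it is.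

Among the measured compounds shown here, no measured step covers this exact change, so the evidence is indirect. The closest measured step replaces 3-nitrophenyl with 3,4,5-trimethoxyphenyl at the same place, and it is small: a 1.1-fold lower number from compound 2 to compound 3 (0.05 log units; within the scatter). Compound 1 already carries 3,5-dimethoxyphenyl and gives 11400 nM, which is within the scatter of compound 3. These three compounds show no sensitivity to the substituents tried so far, though they are few. No step beyond the scatter is therefore expected in this assay, and no direction is favoured.

The estimated step is a 1.1-fold lower number from compound 3 to compound 4 (0.03 log units; within the scatter). For compound 4 the expected value is 12500 nM, with an estimated range of 7500 nM to 20000 nM.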

Compound 4, half-maximal inhibitory concentration: 14000 nM
For compound 4 the middle estimate is 1.1-fold (0.05 log units) below the measured one; the measured number falls inside the stated range.
By their numbers in this assay, from the lowest: compounds 1, 3, 4 and 2 (each within the scatter of the next).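

Hydrogen in place of the methoxy group on the 3,4,5-trimethoxyphenyl ring, at the carbon para to a large group, gives the first direct reading of this position in this assay (a 1.1-fold higher number from compound 3 to compound 4 (0.02 log units; within the scatter)), so with the 2-fluorophenyl group held, this methoxy group can go without a step beyond the scatter. The 3,5-dimethoxyphenyl group also cannot be separated from 3-nitrophenyl with that partner held (a 1.1-fold lower number from compound 2 to compound 4 (0.03 log units; within the scatter)), and 2-fluorophenyl in place of 3,5-dimethoxyphenyl at the other arm gives no step beyond the scatter either (a 1.2-fold higher number from compound 1 to compound 4 (0.09 log units; within the scatter)). These three readings extend the flat picture to a direct step at this carbon, and nothing measured here offers an account of that flatness.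

Open is whether a group of another kind at this carbon, such as an amine or a carboxylic acid, would give a step beyond the scatter, since the aryl substituents shown are only methoxy, nitro and fluoro. The 4-fluorophenyl group on the sulfonyl is the same in all four compounds, so what a different group there, such as a longer alkyl chain, would do remains unread.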